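This account rests on a few compounds, and the source may have more. Where it says the series, first, only, none or still open, it means among the compounds named here.

Compound 3 `N#Cc1ccccc1CN1C(=O)N(Cc2ccccc2)S(=O)(=O)n2cccc21` stops at a limit of the assay: in an ADME assay on MT4 cells (Homo sapiens) for cytotoxicity, read by MTT assay, with a stated time of 5 days (a lower number here means that less compound is tolerated, a higher number that more compound is tolerated), compound 3 gives > 318000 nM. Compound 1 `C=CCN1C(=O)N(Cc2ccccc2)S(=O)(=O)n2cccc21` likewise stops at a limit; in this assay compound 1 gives > 802000 nM. For the measured compounds named here, compound 2 `O=C1N(Cc2ccccc2)c2cccn2S(=O)(=O)N1Cc1ccccc1` in this assay gives 196000 nM, the one plain number of the three. Compound 4 `O=C1N(Cc2ccccc2Br)c2cccn2S(=O)(=O)N1Cc1ccccc1` differs from compound 3 by bromo in place of cyano on an aromatic carbon. The measured step that touches this aromatic carbon is an at least 1.6-fold higher number from compound 2 to compound 3 (0.21 log units; that floor lies within the scatter), while an at least 4.0-fold lower number from compound 1 to compound 2 (0.61 log units; beyond the scatter) and a step that the two limits leave unreadable from compound 1 to compound 3 concern the larger swap away from vinyl. Nothing seen here points to a step beyond the scatter, so for compound 4 the expected step is an at least 1.1-fold lower number from compound 3 to compound 4 (0.05 log units; that floor lies within the scatter). Compound 4 is therefore estimated at 280000 nM, with a range from 110000 nM to 800000 nM, and a limit rather than a number is quite possible.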

Compound 4, half-maximal cytotoxic concentration: 226000 nM
The estimate for compound 4 lay 1.2-fold (0.09 log units) above the measured number; measured number inside the range.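

In this assay, bromo at this aromatic carbon cannot be told apart from hydrogen: a 1.2-fold higher number from compound 2 to compound 4 (0.06 log units; within the scatter). Bromo and cyano are not separated either, since the comparison gives only a floor: an at least 1.4-fold lower number from compound 3 to compound 4 (0.14 log units; that floor lies within the scatter). The larger swap away from vinyl still stands out with bromo on the ring, as an at least 3.5-fold lower number from compound 1 to compound 4 (0.55 log units; beyond the scatter).

As far as these compounds go, compound 3 stops at a limit, so its true distance from compound 4 stays open: the limit of > 318000 nM in this assay, at which 1 of the 4 values shown sits. From the compounds shown here alone, whether an amine or a carboxylic acid on this aromatic carbon would move the number beyond the scatter also remains open.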